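This account rests on a few compounds, and the source may have more. Where it says the series, first, only, none or still open, it means among the compounds named here.

Working notes on the series, all read in a functional assay on PC-3 cells (Homo sapiens) for inhibition, read by sulforhodamine B assay, with a stated time of 48 h, tested at 50 uM; a higher number here means more inhibition of growth at the concentration tested, a lower number less inhibition of growth. For the measured compounds named here, compound 1 (`COc1cc(/C=C/C(=O)/C=C/c2cccc3ccccc23)ccc1OCc1cn(CCOc2cc(=O)oc3ccccc23)nn1`) gives 20%, the only numerical reading so far. Compound 2 (`COc1ccccc1/C=C/C(=O)/C=C/c1ccc(OCc2cn(CCCOc3cc(=O)oc4ccccc34)nn2)c(OC)c1`) is recorded as "not active" (no number reported), with no number reported. Compound 3 (`COc1cc(/C=C/C(=O)/C=C/c2ccccc2)ccc1OCc1cn(CCCCOc2cc(=O)oc3ccccc23)nn1`) is likewise recorded as "not active" (no number reported), so it has no single number and offers only a qualitative starting point. Going by the values given here, the three measured compounds differ from one another in more than one place, and no single-change step between them is available.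

Compound 4 (`COc1cc(/C=C/C(=O)/C=C/c2cc(OC)c(OC)c(OC)c2)ccc1OCc1cn(CCCCOc2cc(=O)oc3ccccc23)nn1`) departs from compound 3 in one place: it carries 3,4,5-trimethoxyphenyl in place of phenyl on a double-bonded chain carbon bound to a double-bonded chain carbon. Among the compounds with values here, no measured compound carries this group, so the data give no direct guide to its effect.

Starting from compound 3 at "not active" (no number reported), the step expected in this assay is small and upward, possibly no larger than the usual scatter, and another reading without a number remains a real possibility. The upper part of the expected range is guided by compound 1 at 20%. For compound 4, the estimated growth inhibition is 12%, with an expected range of 0% to 30%.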

Compound 4, percent growth inhibition at one concentration: 5%
Compound 4: the middle estimate sits 7 percentage points above what was measured, and the stated range covers the measured number.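

For the compounds shown here, with compound 3 at "not active" (no number reported) and compound 4 at 5% in this assay no step between the two can be read. The compounds shown leave open whether 3,4,5-trimethoxyphenyl in place of phenyl changes growth inhibition at all. No evidence at hand bears on this result.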